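Moving from ethoxy to isobutoxy on the core of compound 3

This account rests on a few compounds, and the source may have more. Where it says the series, first, only, none or still open, it means among the compounds named here.

Of the compounds shown here, three have so far been measured in a functional assay for agonist activity at Bile acid receptor (Homo sapiens), read by FRET; on this read-out lower numbers stand for an effect already at smaller amounts and higher numbers for an effect only at larger amounts of compound. Compound 1 `CC(C)c1onc(-c2c(Cl)cccc2Cl)c1COc1ccc(-c2ccc3c(C(=O)O)ccnc3c2)cc1` gives 340 nM, compound 2 `CC(C)c1onc(-c2c(Cl)cccc2Cl)c1COc1ccc(-c2ccc3nc(C(=O)O)cnc3c2)cc1` gives 150 nM, and compound 3 `CCOc1cc(C(=O)O)nc2ccc(-c3ccc(OCc4c(-c5c(Cl)cccc5Cl)noc4C(C)C)cc3)cc12` gives 52 nM. Compound 3 thus stands at the lowest of the three numbers; its nearest neighbour is compound 2, whose number lies higher by a margin beyond the usual scatter, and compound 1 lies further away still, also beyond the scatter. No two of these compounds differ in only one place, so no single-point step can be read among them; only the values themselves are known.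

Compound 4 `CC(C)COc1cc(C(=O)O)nc2ccc(-c3ccc(OCc4c(-c5c(Cl)cccc5Cl)noc4C(C)C)cc3)cc12` has not yet been measured. It differs from compound 3 in one place: isopropyl in place of methyl on a saturated chain carbon bound to an oxygen on an aromatic ring. Going by the values given here, since no step between measured compounds exists here, nothing in the measured set tells how a change of this kind has behaved before, and the expectation rests on the change alone. In this assay compound 4 is expected to give about 60 nM, within a range from 20 nM to 180 nM. The expected step of a 1.2-fold higher number from compound 3 to compound 4 (0.06 log units; within the scatter) is therefore estimated to stay within the usual scatter, in no clear direction.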

Compound 4, half-maximal effective concentration: 78 nM
Estimate against measurement, compound 4: 1.3-fold (0.11 log units) below; low and high end bracket the measured number.
By their numbers in this assay, from the lowest: compounds 3, 4 and 2 (each within the scatter of the next, the first and the last beyond it); then compound 1.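

In this assay, going by these compounds alone, the replacement of methyl by isopropyl on a saturated chain carbon bound to an oxygen on an aromatic ring gives a 1.5-fold higher number from compound 3 to compound 4 (0.18 log units; within the scatter) as the first step in this set between compounds that differ in one place. Ethoxy and isobutoxy therefore cannot be told apart on this read-out, and this position tolerates the larger isobutoxy chain without a shift beyond the usual scatter, something the earlier compounds, with no single-place pair among them, could not show. No accompanying data bear on why the two compounds stay so close.

From the compounds shown here alone, the step covers only these two chains, so it remains open whether a longer chain, a cyclopropyl ring or an amine carried on the same oxygen would also leave the number within the scatter of compound 3. A single step also cannot say whether the same change from ethoxy to isobutoxy would behave alike on a different core.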